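The compounds below may be only part of what the source reports. "The series", "measured", "known", "first", "only" and "open" are said of these compounds alone.

Compound 1 `CN(c1ccc(Oc2ncnc3ccsc23)cc1)c1nccc(N2CCc3ccccc3C2)n1` and compound 2 `CN(c1ccc(Oc2ncnc3ccsc23)cc1)c1nccc(N2CCc3ccccc32)n1` share one core. In a functional assay on HCT-116 cells (Homo sapiens) for inhibition, read by MTT assay, with a stated time of 72 h, tested at 20 uM (a higher number here means more inhibition at the concentration tested (going by the name of the read-out), a lower number less inhibition), compound 1 gives 58.3%, and compound 2 gives 57.8%. Among the measured compounds shown here, the single change between them is 2,3-dihydro-1H-indol-1-yl in place of 1,2,3,4-tetrahydroisoquinolin-2-yl on an aromatic carbon, and it made a number 0.5 percentage points lower from compound 1 to compound 2 (within the scatter). Compound 3 `c1ccc2c(c1)CCN(c1ccnc(Nc3ccc(Oc4ncnc5sccc45)cc3)n1)C2` is built on a different core; how the two cores differ is not broken down here. In this assay compound 3 gives 18.1%, the lowest of the three numbers. Compound 4 `c1ccc2c(c1)CCN2c1ccnc(Nc2ccc(Oc3ncnc4sccc34)cc2)n1` has not yet been measured. It arises from compound 3 through the same change, (2,3-dihydro-1H-indol-1-yl in place of 1,2,3,4-tetrahydroisoquinolin-2-yl on an aromatic carbon), at the same place. Because the same change made a number 0.5 percentage points lower from compound 1 to compound 2 (within the scatter), a similarly small step is expected here too, estimated as a number 0.5 percentage points lower from compound 3 to compound 4 (within the scatter). Compound 4 is therefore expected to give about 17.6%, most likely between 6% and 32%.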

Compound 4, a percentage reported as inhibition, at one concentration (the size of the read-out at that concentration, not a potency): -0.62%
Beside the measured number, compound 4's estimate is 18.2 percentage points above it, outside the stated range (below it).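

Replacing 1,2,3,4-tetrahydroisoquinolin-2-yl with 2,3-dihydro-1H-indol-1-yl gave a number 18.7 percentage points lower from compound 3 to compound 4 (beyond the scatter) in this assay, so the change did not carry over between the two cores with the same size: the same change on two cores in this assay, a number 0.5 percentage points lower (within the scatter) from compound 1 to compound 2 and a number 18.7 percentage points lower (beyond the scatter) from compound 3 to compound 4, 18.2 percentage points apart, beyond the scatter of two such steps

In these two pairs, then, the size of the step depends on the core, and a step seen on one core cannot simply be copied to the other. This does not show which part of the core is responsible, and with one pair per core and a read-out at a single concentration, it says nothing about potency or about any other core.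

On these data alone, it remains open which difference between the cores matters. As far as these compounds go, it also remains open whether other groups at this place, such as piperidine or morpholine, would also give different steps on the two cores.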